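Cytotoxicity of a dipeptide-linked thymine nucleoside series

The source may report more compounds than this note shows. Statements on the series, on what has been measured and on what is new or still open speak of the compounds shown alone.

Compound 1 `Cc1cn(C2OC(CO[Si](C)(C)C(C)(C)C)C3(OS(=O)(=O)C=C3N)C2O[Si](C)(C)C(C)(C)C)c(=O)n(CCCNC(=O)[C@@H]2CCCN2C(=O)[C@@H](N)C(C)C)c1=O`: 11000 nM in a functional assay on MT4 cells (Homo sapiens) for antiproliferative activity; on this read-out lower numbers stand for higher toxicity in this test and higher numbers for lower toxicity in this test
Compound 2 `Cc1cn(C2OC(CO[Si](C)(C)C(C)(C)C)C3(OS(=O)(=O)C=C3N)C2O[Si](C)(C)C(C)(C)C)c(=O)n(CCCNC(=O)[C@@H]2CCCN2C(=O)[C@@H](N)CCCCN)c1=O`: 87000 nM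

Compound 2 gives the highest of the two numbers in this assay, with compound 1 the nearer neighbour at a 7.9-fold higher number from compound 1 to compound 2 (0.90 log units; beyond the scatter). Compound 3 `Cc1cn(C2OC(CO[Si](C)(C)C(C)(C)C)C3(OS(=O)(=O)C=C3N)C2O[Si](C)(C)C(C)(C)C)c(=O)n(CCCNC(=O)[C@@H]2CCCN2C(=O)[C@@H](N)CCC(=O)O)c1=O` differs from compound 2 by carboxy in place of 2-aminoethyl on a saturated chain carbon, three bonds along the chain from an amine nitrogen and a carbonyl carbon. Among the measured compounds shown here, no measured step carries this change; the only step known, a 7.9-fold higher number from compound 1 to compound 2 (0.90 log units; beyond the scatter), concerns another exchange at the same chain carbon and shows how far a single side-chain swap can move this read-out. Compound 3 is therefore expected near compound 2, with a step of a 1.7-fold lower number from compound 2 to compound 3 (0.24 log units; within the scatter). The estimate for compound 3 is 50000 nM, within 15000 nM to 160000 nM.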

Compound 3, half-maximal cytotoxic concentration: 64000 nM
Beside the measured number, compound 3's estimate is 1.3-fold (0.11 log units) below it; low and high end bracket the measured number.
By their numbers in this assay, from the lowest: compound 1; then compounds 3 and 2 (each within the scatter of the next).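

In this assay, carboxy in place of 2-aminoethyl at this chain carbon stays within the scatter (a 1.4-fold lower number from compound 2 to compound 3 (0.13 log units; within the scatter)), so an amine or a carboxylic acid at the chain end gives numbers that cannot be told apart. The 2-carboxyethyl chain also stands clear of isopropyl (a 5.8-fold higher number from compound 1 to compound 3 (0.76 log units; beyond the scatter)), so among these three compounds, both longer chains separate from isopropyl whichever end group they carry. From the compounds shown here alone, whether a plain unbranched alkyl chain or a shorter chain ending in an amine would group with compound 2 and compound 3 stays open. No evidence on this result is available.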